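Ester Variation and Stability in Human Liver Microsomes

The source may hold more compounds than are shown below. What is called first, only, known or untested is meant among the compounds shown, and "the series" means these compounds.

Compound 1, `CCCCc1nc(C(C)C)c(CC(=O)OC)c(=O)n1Cc1ccc(-c2ccccc2-c2noc(=O)[nH]2)cc1`, gives 10.5% in an ADME assay on microsomes from liver (Homo sapiens) for metabolic stability, with a stated time of 30 min; a lower number here means that less of the compound is left, a higher number that more of the compound is left.
Compound 2, `CCCCCOC(=O)Cc1c(C(C)C)nc(CCCC)n(Cc2ccc(-c3ccccc3-c3noc(=O)[nH]3)cc2)c1=O`, gives 10.6% in this assay.
Compound 3, `CCCCc1nc(C(C)C)c(CC(=O)OCC(C)C)c(=O)n1Cc1ccc(-c2ccccc2-c2noc(=O)[nH]2)cc1`, gives 8.8% in this assay.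

Compound 3 sits at the low end of these three numbers, yet both of its gaps lie within the scatter: a number 1.7 percentage points lower from compound 1 to compound 3 (within the scatter) and a number 1.8 percentage points lower from compound 2 to compound 3 (within the scatter). Compound 4, `CCCCc1nc(C(C)C)c(CC(=O)OC(CC)CC)c(=O)n1Cc1ccc(-c2ccccc2-c2noc(=O)[nH]2)cc1`, differs from compound 3 by pentan-3-yl in place of isobutyl on an oxygen next to a carbonyl group. Among the measured compounds shown here, the steps that bear on this are all changes of the same ester group: a number 0.1 percentage points higher from compound 1 to compound 2 (within the scatter), a number 1.7 percentage points lower from compound 1 to compound 3 (within the scatter) and a number 1.8 percentage points lower from compound 2 to compound 3 (within the scatter), none beyond the scatter. A step of no meaningful size is therefore expected in this assay, that is a number 0.7 percentage points higher from compound 3 to compound 4 (within the scatter). Compound 4 is estimated at 9.5%, within a range from 4% to 18%.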

Compound 4, percent of the compound remaining: 7.7%
For compound 4 the middle estimate is 1.8 percentage points above the measured one, within the range that was stated.
By their numbers in this assay, from the lowest: compounds 4, 3, 1 and 2 (each within the scatter of the next).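

Pentan-3-yl on the oxygen next to a carbonyl group gives no step beyond the scatter in this assay against any of the three earlier ester groups: isobutyl (a number 1.1 percentage points lower from compound 3 to compound 4 (within the scatter)), pentyl (a number 2.9 percentage points lower from compound 2 to compound 4 (within the scatter)) and methyl (a number 2.8 percentage points lower from compound 1 to compound 4 (within the scatter)). Across these four compounds, then, changing this ester group has not moved the number beyond the scatter. Nothing available explains this. The compounds shown leave open whether a carboxylic acid or an amide in place of the ester, or cyclohexyl on this oxygen, would give a step beyond the scatter.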